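The compounds below may be only part of what the source reports. "The series", "measured", "known", "first", "only" and "open" are said of these compounds alone.

Working notes on the series.

Compound 2, `C[C@@H](NC(=O)Nc1cccc(F)c1)c1ccccc1`, is one of two measured compounds in an ADME assay on the whole organism with Oryza sativa as the target, tested at 1 uM (on this read-out higher numbers stand for a weaker effect at the one concentration tested and lower numbers for a stronger effect), where compound 2 gives 95%. Among the compounds with values here, its only neighbour is compound 1, `Cc1cccc(NC(=O)N[C@H](C)c2ccccc2)c1`, which in this assay gives 98%; the difference between the two, a number 3 percentage points lower from compound 1 to compound 2 (within the scatter), is fluoro in place of methyl on an aromatic carbon and falls within the usual scatter, so compound 2 and compound 1 stand together and neither can be set apart from the other.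

Compound 3, `C[C@@H](NC(=O)Nc1cccc(Br)c1)c1ccccc1`, is not yet measured. It differs from compound 2 as follows: bromo in place of fluoro on an aromatic carbon. Within the data shown here, the only measured step in the set, fluoro in place of methyl at the same aromatic carbon, is a number 3 percentage points lower from compound 1 to compound 2 (within the scatter) and stays within the scatter. Among the measured compounds shown here, no step for bromo in place of fluoro exists in the measured pairs, so the expectation rests on that single halogen exchange, which moved the read-out not at all beyond the scatter.

The step expected a number 1 percentage points lower from compound 2 to compound 3 (within the scatter) is therefore none beyond the scatter.

For compound 3 the estimated value in this assay is 94%, with a range from 84% to 100%.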

Compound 3, a percentage reported as activity, at one concentration (the size of the read-out at that concentration, not a potency): 100%
The estimate for compound 3 lay 6 percentage points below the measured number; the range from low to high includes it.
By their numbers in this assay, from the lowest: compounds 2, 1 and 3 (each within the scatter of the next).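

In this assay, bromo in place of fluoro on this aromatic carbon gives a number 5 percentage points higher from compound 2 to compound 3 (within the scatter), and bromo in place of methyl gives a number 2 percentage points higher from compound 1 to compound 3 (within the scatter); both steps stay within the scatter. Where the earlier compounds offered a single exchange at this place, on an aromatic carbon of a six-membered aromatic ring of carbon only, meta to a large group, methyl, fluoro and bromo can now all be compared there, and no exchange among the three separates one compound from another at the one concentration tested. Nothing available explains why these exchanges leave the compounds together on this read-out.

The compounds shown leave open whether a group of a different kind at this place, such as an amine, a carboxylic acid or a longer alkyl chain, would produce a step beyond the scatter. They also leave open whether a change elsewhere on the shared core would move the read-out, and whether any such step would hold at another concentration.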